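Notes on the series: from compound 3 to compound 4

A few compounds are considered here, and "the series" means these few. Any claim that something is new, unique, unknown or untested is made for them only; others in the source may bear on it.

The three measured compounds share one core and differ only at the far end of a short saturated chain. Compound 1 `O=c1cc(Cn2cc(CCCCl)nn2)c2ccc(O)cc2o1` ends in a chloro. In a functional assay on HepG2 cells (Homo sapiens) for inhibition, read by MTT assay, with a stated time of 72 h (a lower number here means a stronger inhibitor, a higher number a weaker inhibitor), compound 1 gives > 100000 nM, which is a limit of the assay and not a number. Compound 2 `O=c1cc(Cn2cc(CCCCO)nn2)c2ccc(O)cc2o1` ends in a hydroxy. In this assay compound 2 gives > 100000 nM, again a limit rather than a number. Compound 3 `CCCCCCCCc1cn(Cc2cc(=O)oc3cc(O)ccc23)nn1` carries an octyl chain instead. In this assay, among the compounds with values here, compound 3 gives 34200 nM, the only number in the set, the two other values sitting at the limit of > 100000 nM in this assay, at which 2 of the 3 values shown sit.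

The steps to compound 3 read an at least 2.9-fold lower number from compound 1 to compound 3 (0.46 log units; beyond the scatter) and an at least 2.9-fold lower number from compound 2 to compound 3 (0.46 log units; beyond the scatter), while the step that the two limits leave unreadable from compound 1 to compound 2 cannot be sized.

Compound 4 `O=c1cc(Cn2cc(CCc3ccccc3)nn2)c2ccc(O)cc2o1` differs from compound 3 by phenyl in place of hexyl on a saturated chain carbon, two bonds along the chain from an aromatic carbon. Within the data shown here, no measured step exchanges a chain for a ring, so the two steps into compound 3 bear on it only loosely: a chain with no hydrogen-bond donors or acceptors gave a lower number than chloro or hydroxy, and phenyl likewise carries none. In this assay a step within the scatter is expected, if anything slightly upward. Compound 4 is estimated at 45000 nM, with a range from 15000 nM to 100000 nM. The expected step is a 1.3-fold higher number from compound 3 to compound 4 (0.12 log units; within the scatter).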

Compound 4, half-maximal inhibitory concentration: 50500 nM
Estimate against measurement, compound 4: 1.1-fold (0.05 log units) below; the measured number falls inside the stated range.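

Phenyl in place of hexyl, each of 6 heavy atoms, puts an aromatic ring at this place for the first time in the series, and this assay does not separate the two ends (a 1.5-fold higher number from compound 3 to compound 4 (0.17 log units; within the scatter)). An end group with no ring is therefore not needed to keep a measurable number here, and compound 4 reads as a second measured value alongside compound 3, with no order between them. Against the chloro and hydroxy ends the comparison stays weak, at (an at least 1.9-fold lower number from compound 2 to compound 4 (0.29 log units; that floor lies within the scatter)) and (an at least 1.9-fold lower number from compound 1 to compound 4 (0.29 log units; that floor lies within the scatter)), and these floors can be given only as such because compound 1 and compound 2 each stand at a limit of the assay, not at a number: the limit of > 100000 nM in this assay, at which 2 of the 4 values shown sit.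

The step between compound 1 and compound 2 still cannot be read. Going by these compounds, whether the number follows the ring itself or only the size of the end group stays open, as does the effect of an amine or a carboxylic acid at the chain end, a longer chain such as decyl, or a fluoro or methoxy group on the phenyl.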